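A few compounds are considered here, and "the series" means these few. Any claim that something is new, unique, unknown or untested is made for them only; others in the source may bear on it.

Measured in an assay on LX2 cells for inhibition of COL1A1 promoter (Homo sapiens), read by a luciferase reporter, with a stated time of 24 h, tested at 50 uM; on this read-out higher numbers stand for a stronger effect at the one concentration tested and lower numbers for a weaker effect:

compound 1 `Cc1cc(OCCCCCCC[N+]2(C)CCCC2)cc(-n2cc(C(=O)Nc3cc(F)cc(F)c3)c(=O)c3ccc(N(C)C)nc32)c1` gives 35.4%
compound 2 `Cc1cc(OCCCCCCC[N+]2(C)CCCCC2)cc(-n2cc(C(=O)Nc3cc(F)cc(F)c3)c(=O)c3ccc(N(C)C)nc32)c1` gives 79.7%
compound 3 `Cc1ccc(-n2cc(C(=O)Nc3cc(F)cc(F)c3)c(=O)c3ccc(N(C)C)nc32)cc1OCCCCCCC[n+]1ccccc1` gives 22.2%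

Compound 2 stands highest of the three numbers. For the measured compounds named here, its nearest neighbour is compound 1, and the gap a number 44.3 percentage points higher from compound 1 to compound 2 (beyond the scatter) is the only single-site step among the measured compounds. Going by the values given here, compound 3 shows the lowest number of the three; no single-site step connects it to compound 2, so only the two values themselves can be compared.

Compound 4 `Cc1cc(OCCCCCCC[N+]2(C)CCN(C)CC2)cc(-n2cc(C(=O)Nc3cc(F)cc(F)c3)c(=O)c3ccc(N(C)C)nc32)c1` differs from compound 2 in one place: a group of 8 heavy atoms (6 carbon, 2 nitrogen; one six-membered non-aromatic ring with 2 hetero atoms) in place of a group of 7 heavy atoms (6 carbon, 1 nitrogen; one six-membered non-aromatic ring with 1 hetero atom), on a saturated chain carbon, seven bonds along the chain from an oxygen on an aromatic ring.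

Among the compounds with values here, the one step that bears on this change is a number 44.3 percentage points higher from compound 1 to compound 2 (beyond the scatter), which shows that the make-up of the cationic ring at this chain position can move the read-out in this assay by a large amount. Within the data shown here, no measured step covers the entry of a second ring nitrogen, so the direction of the step from compound 2 to compound 4 is not settled by the data, and a step in either direction beyond the scatter is possible.

On balance compound 4 is expected to sit somewhat below compound 2, with the step of a number 24.7 percentage points lower from compound 2 to compound 4 (beyond the scatter) estimated as moderate and downward. The expected value for compound 4 in this assay is 55%, with a range from 20% to 85%.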

Compound 4, a percentage reported as inhibition, at one concentration (the size of the read-out at that concentration, not a potency): 38.2%
For compound 4 the middle estimate is 16.8 percentage points above the measured one; measured number inside the range.
By their numbers in this assay, from the lowest: compound 3; then compounds 1 and 4 (each within the scatter of the next); then compound 2.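

Keeping the ring six-membered does not keep the read-out in this assay: the ring with 2 hetero atoms in place of the ring with 1 hetero atom gives a number 41.5 percentage points lower from compound 2 to compound 4 (beyond the scatter), so ring size alone does not set the high number of compound 2. Set against the five-membered ring, the same group gives a number 2.8 percentage points higher from compound 1 to compound 4 (within the scatter), which leaves compound 2 apart from both other saturated rings at this chain carbon in this assay. Nothing available explains why this one ring stands apart.

Still open, going by these compounds, is whether the second ring nitrogen or the methyl on it goes with the lower number, a question that a morpholine or an unsubstituted piperazine at the same chain carbon would address. Also open, on these data alone, is how the ring of compound 2 behaves on a shorter or longer chain.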